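Acetylating the Side-Chain Hydroxyl of Compound 1

The source may report more compounds than this note shows. Statements on the series, on what has been measured and on what is new or still open speak of the compounds shown alone.

Compound 1 `CC(C)[C@@H](O)CNC(C)(C)CC(=O)N[C@@H]1CCc2ccccc2N(Cc2ccc(-c3ccccc3-c3nn[nH]n3)cc2)C1=O` — 200 nM
Compound 2 `C[C@H](O)CNC(C)(C)C(=O)N[C@@H]1CCc2ccccc2N(Cc2ccc(-c3ccccc3-c3nn[nH]n3)cc2)C1=O` — 700 nM
Compound 3 `C[C@@H](O)CCNC(C)(C)C(=O)N[C@@H]1CCc2ccccc2N(Cc2ccc(-c3ccccc3-c3nn[nH]n3)cc2)C1=O` — 100 nM

All three compounds share one core and differ only in the chain that carries a hydroxyl group. In a functional assay (Pituitary gland cell) with Rattus norvegicus as the target (on this read-out lower numbers stand for an effect already at smaller amounts and higher numbers for an effect only at larger amounts of compound), compound 1 stands second highest of the three numbers: compound 3 lies nearest with a 2.0-fold lower number from compound 1 to compound 3 (0.30 log units; within the scatter), and compound 2 furthest with a 3.5-fold higher number from compound 1 to compound 2 (0.54 log units; beyond the scatter). Between the other two the step is a 7.0-fold lower number from compound 2 to compound 3 (0.85 log units; beyond the scatter), so shifting the hydroxyl along this chain has moved the read-out by a modest amount.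

Compound 4 `CC(=O)O[C@@H](C)CNC(C)(C)CC(=O)N[C@@H]1CCc2ccccc2N(Cc2ccc(-c3ccccc3-c3nn[nH]n3)cc2)C1=O` is not yet measured. It differs from compound 1 by 1-acetoxyethyl in place of 1-hydroxy-2-methylpropyl on a saturated chain carbon bound to an amine nitrogen. The measured steps all keep a free hydroxyl, so none shows directly what capping it as an ester does; they only show that this region tolerates rearrangement with modest shifts. The expected step is therefore a 2.0-fold higher number from compound 1 to compound 4 (0.30 log units; within the scatter), a somewhat higher number, with wide uncertainty. Compound 4 is estimated at 400 nM in this assay, within 100 nM to 2000 nM.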

Compound 4, concentration for half-maximal effect: 200 nM
Compound 4: the middle estimate sits 2.0-fold (0.30 log units) above what was measured; the measured number falls inside the stated range.
By their numbers in this assay, from the lowest: compounds 3, 1 and 4 (each within the scatter of the next); then compound 2.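

Compound 4 shows that a free hydroxyl is not required on this chain: 1-acetoxyethyl, with 0 hydrogen-bond donors, replaces 1-hydroxy-2-methylpropyl, with 1 hydrogen-bond donor, and this assay gives no change at the digits printed from compound 1 to compound 4 (within the scatter) for this change. The ester chain also falls within the scatter of one other hydroxyl chain, with a 2.0-fold higher number from compound 3 to compound 4 (0.30 log units; within the scatter) as the step, while a 3.5-fold lower number from compound 2 to compound 4 (0.54 log units; beyond the scatter) keeps it apart from the remaining one. No measurement here explains why the ester is tolerated.

This one step replaces both the hydroxyl and the branched end of the chain, leaving the contribution of each change unresolved. A 1-acetoxy-2-methylpropyl group would separate the two, and a 1-aminoethyl group would test an amine on the same carbon.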